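A few compounds are considered here, and "the series" means these few. Any claim that something is new, unique, unknown or untested is made for them only; others in the source may bear on it.

Compound 1 `O=c1cc(CN(c2ccccc2)c2cccc(Cl)c2)c2ccc(F)c(F)c2[nH]1` was tested in an assay on HEK293 cells for inhibition of Nitric oxide synthase, inducible (Homo sapiens), read by fluorescence (a higher number here means a weaker inhibitor, a lower number a stronger inhibitor), and gives 1500 nM. Compound 2 `O=c1cc(CN(c2cccc(Cl)c2)c2ccccn2)c2ccc(F)c(F)c2[nH]1` in this assay gives 31 nM. Putting pyridin-2-yl in place of phenyl on a nitrogen on an aromatic ring yields a 48-fold lower number from compound 1 to compound 2 (1.68 log units; beyond the scatter). Compound 3 `O=c1cc(CN(Cc2ccccc2)c2cnccn2)c2ccc(F)c(F)c2[nH]1` stands lowest of the three numbers, with 13 nM in this assay; its nearest neighbour is compound 2, and compound 1 lies furthest from it.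

Compound 4 `O=c1cc(CN(Cc2ccccc2Cl)c2cnccn2)c2ccc(F)c(F)c2[nH]1` has not yet been measured. It differs from compound 3 in a single place: chloro in place of hydrogen on an aromatic carbon, ortho to a large group, so that the benzyl becomes a 2-chlorobenzyl. Among the measured compounds shown here, no measured step speaks to this change. For the measured compounds named here, the only step in hand, a 48-fold lower number from compound 1 to compound 2 (1.68 log units; beyond the scatter), swaps one aromatic ring for another on the nitrogen and says nothing about adding a chloro to a benzyl ring. With nothing comparable to lean on, the expectation is that the step from compound 3 to compound 4 stays within the scatter, namely no change at the digits printed from compound 3 to compound 4 (within the scatter), with no firm direction. Compound 4 is therefore estimated at 13 nM in this assay, with a range from 4 nM to 45 nM.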

Compound 4, half-maximal inhibitory concentration: 12 nM
The estimate for compound 4 lay 1.1-fold (0.03 log units) above the measured number; measured number inside the range.
By their numbers in this assay, from the lowest: compounds 4 and 3 (each within the scatter of the next); then compound 2; then compound 1.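

In this assay, chloro in place of hydrogen on an aromatic carbon, ortho to a large group, turns the benzyl into a 2-chlorobenzyl and gives a 1.1-fold lower number from compound 3 to compound 4 (0.03 log units; within the scatter), so compound 3 and compound 4 cannot be told apart. Among the compounds shown here, the earlier compounds showed only that a swap of one aromatic ring for another on the nitrogen can matter a great deal, as in a 48-fold lower number from compound 1 to compound 2 (1.68 log units; beyond the scatter); this pair adds that the benzyl ring can carry one extra heavy atom at this place with no readable shift in the number. Nothing measured here explains why the number holds steady.

As far as these compounds go, a single chloro at a single place says little about the benzyl ring as a whole, so it remains open whether a methoxy group, an amine or a carboxylic acid at the same carbon would leave the number just as steady. From the compounds shown here alone, it is also open whether a larger ring or a longer chain in place of the benzyl would fit this pattern, or whether this chloro would behave the same way with a different ring on the nitrogen.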